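A naphthalenyl to phenyl swap on a sulfonamide scaffold

A few compounds are considered here, and "the series" means these few. Any claim that something is new, unique, unknown or untested is made for them only; others in the source may bear on it.

In a functional assay on DLD-1 cells (Homo sapiens) for antiproliferative activity, read by CellTiter-Glo, with a stated time of 72 h (on this read-out higher numbers stand for weaker inhibition and lower numbers for stronger inhibition), compound 1 `CC1CCN(C2CCN(S(=O)(=O)c3ccccc3Br)CC2)CC1` gives 3 nM. Compound 2 `CC1CCN(C2CCN(S(=O)(=O)c3cccc(-c4ccc5ccccc5c4)c3)CC2)CC1` gives 2 nM in this assay, the lowest of the two numbers, although its gap to compound 1 lies within the scatter. Compound 3 `CC1CCN(C2CCN(S(=O)(=O)c3cccc(-c4ccccc4)c3)CC2)CC1` differs from compound 2 by phenyl in place of naphthalen-2-yl on an aromatic carbon. Within the data shown here, no measured pair shows this change, so the size of the step is uncertain. Compound 3 is expected to land a little higher, a step of a 2.0-fold higher number from compound 2 to compound 3 (0.30 log units; within the scatter). Compound 3 is therefore estimated at 4 nM, with a range from 1.5 nM to 12 nM.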

Compound 3, half-maximal inhibitory concentration: 2 nM
Estimate against measurement, compound 3: 2.0-fold (0.30 log units) above, and the stated range covers the measured number.
By their numbers in this assay, from the lowest: compounds 2, 3 and 1 (each within the scatter of the next).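

Going from naphthalen-2-yl to phenyl on this aromatic carbon, meta to a large group, gives in this assay no change at the digits printed from compound 2 to compound 3 (within the scatter). Among these compounds, this is the first direct reading at this position: the group drops from 10 heavy atoms to 6 and from two six-membered aromatic rings to one, with no step beyond the scatter. Nothing available explains this result. The compounds shown leave open whether an amine, a carboxylic acid or a methyl group in place of phenyl on this carbon would stay within the scatter of compound 3.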